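Chloro in place of hydrogen on a fused benzothiazole-type core

The source may hold more compounds than are shown below. What is called first, only, known or untested is meant among the compounds shown, and "the series" means these compounds.

Measured compounds:
compound 1, `Cc1cnc(Nc2ccc(S(C)(=O)=O)cc2)nc1Nc1nc2ccc(Cl)cc2s1`, gives 2500 nM in a functional assay on HCT-116 cells (Homo sapiens) for antiproliferative activity, read by MTT assay, with a stated time of 48 h; a lower number here means a stronger inhibitor, a higher number a weaker inhibitor
compound 2, `Cc1cnc(Nc2ccc(S(C)(=O)=O)cc2)nc1Nc1nc2ccccc2s1`, gives 760 nM in this assay
compound 3, `NS(=O)(=O)c1ccc(Nc2ncc(F)c(Nc3nc4ccccc4s3)n2)cc1`, gives 3260 nM in this assay

Compound 1 and compound 2 share one core and differ in a single change, (chloro in place of hydrogen on an aromatic carbon). That change gave a 3.3-fold higher number from compound 2 to compound 1 (0.52 log units; beyond the scatter), so in this assay the chloro compound is the weaker inhibitor of the pair.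

Compound 3 carries a different core; how it differs from the core of compound 2 is not broken down here. Its value is within the scatter of compound 1 and beyond the scatter of compound 2.

Compound 4, `NS(=O)(=O)c1ccc(Nc2ncc(F)c(Nc3nc4ccc(Cl)cc4s3)n2)cc1`, has not yet been measured. It differs from compound 3 by chloro in place of hydrogen on an aromatic carbon, the same change that turned compound 2 into compound 1, in a place described in the same words.

Because a 3.3-fold higher number from compound 2 to compound 1 (0.52 log units; beyond the scatter) was a modest weakening, compound 4 is expected to show a step of similar size from compound 3, a 2.8-fold higher number from compound 3 to compound 4 (0.44 log units; beyond the scatter), in this assay. Compound 4 is therefore estimated at 9000 nM, with a range from 3500 nM to 25000 nM; this rests on one earlier pair only.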

Compound 4, half-maximal inhibitory concentration: 8620 nM
Compound 4: the middle estimate sits 1.0-fold (0.02 log units) above what was measured; the measured number falls inside the stated range.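

In this assay, chloro in place of hydrogen on an aromatic carbon again gave the weaker inhibitor of the pair, with a 2.6-fold higher number from compound 3 to compound 4 (0.42 log units; beyond the scatter). Set beside the earlier pair, the two steps point the same way and do not differ in size by more than repeated measurements would allow: the same change on two cores in this assay, a 3.3-fold higher number (0.52 log units; beyond the scatter) from compound 2 to compound 1 and a 2.6-fold higher number (0.42 log units; beyond the scatter) from compound 3 to compound 4, 1.2-fold (0.09 log units) apart, within the scatter of two such steps

So on these two cores the change carried over from one to the other with its effect intact, but two pairs in one cell assay cannot show that it would hold on any further core, and they do not explain why the number rises.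

The compounds shown leave open what other groups on this same aromatic carbon, such as a methoxy group, an amine or a nitrile, would do to the number. They also leave open how much each part of the core matters on its own, since the difference between the cores of compound 2 and compound 3 is not broken down into single changes.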